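A Third Nitrogen Substituent Against an Assay Limit

The source may report more compounds than this note shows. Statements on the series, on what has been measured and on what is new or still open speak of the compounds shown alone.

In a functional assay on L02 cells (Homo sapiens) for inhibition, read by Griess assay, with stated times of 1 h and 24 h (a lower number here means a stronger inhibitor, a higher number a weaker inhibitor), compound 1 (`CC(C)Nc1nc(/C=C/c2ccccc2)nc2ccsc12`) gives > 1000000 nM as a limit of the assay and not as a number. Compound 2 (`COc1ccc(Nc2nc(/C=C/c3ccccc3)nc3ccsc23)cc1`) gives > 1000000 nM as a limit as well, so its standing cannot be read as a number. For the measured compounds named here, the only measured step is a step that the two limits leave unreadable from compound 1 to compound 2 and it has no readable size. The evidence so far is the limit of > 1000000 nM in this assay, at which 2 of the 2 values shown sit, with no numerical value yet seen in this assay for this series.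

Compound 3 (`Fc1ccc(CNc2nc(/C=C/c3ccccc3)nc3ccsc23)cc1`) carries 4-fluorobenzyl in place of 4-methoxyphenyl on a nitrogen on an aromatic ring, a change counted as 4-fluorobenzyl in place of 4-methoxyphenyl on a nitrogen on an aromatic ring at that one place. The measured step at the same nitrogen, a step that the two limits leave unreadable from compound 1 to compound 2 gives no size to carry over, so the expectation rests only on both compounds sitting at the limit. No step beyond the scatter is therefore expected, and no direction can be assigned. The estimated step is a number no higher from compound 2 to compound 3 (the limit leaves the size open) in the expected absence of a clear change. Compound 3 is estimated at 1000000 nM with an expected range from 300000 nM to 3000000 nM and a further limit is the likeliest report.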

Compound 3, half-maximal inhibitory concentration: > 1000000 nM
Compound 3 was reported as a limit; the forecaster's own chance of this, stated with the estimate: 75%; the middle value lies on the limit itself.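

In this assay compound 3 gives > 1000000 nM as a limit of the assay and not as a number. For the compounds shown here, no step from compound 1 or compound 2 to compound 3 can be read. The compounds shown leave open whether any group on this nitrogen gives a numerical value in this assay and how these three compounds compare.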